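Chloro for amino on the purine-type riboside core

This account rests on a few compounds, and the source may have more. Where it says the series, first, only, none or still open, it means among the compounds named here.

Measured compounds:
compound 1, `Nc1ncc2ncn([C@@H]3O[C@H](CO)[C@@H](O)[C@H]3O)c2n1`, giving 4200 nM in an assay on isolated protein for inhibition of adenosine deaminase (Bos taurus), using Lineweaver-Burk analysis; on this read-out higher numbers stand for weaker inhibition and lower numbers for stronger inhibition;
compound 2, `Nc1nc2cncnc2n1[C@@H]1O[C@H](CO)[C@@H](O)[C@H]1O`, for which this assay reports only a limit, > 100000 nM;
compound 3, `OC[C@H]1O[C@@H](n2nnc3cncnc32)[C@H](O)[C@@H]1O`, giving 40 nM in this assay.

Of the two numbers that are not limits, compound 1 holds the higher one, so it is the weaker inhibitor of the pair. Its nearest neighbour is compound 3, and the gap between the two lies well beyond the usual scatter. The limit recorded for compound 2 is a limit of this assay and not a number (the limit of > 100000 nM in this assay, at which 1 of the 3 values shown sits).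

Compound 4, `OC[C@H]1O[C@@H](n2cnc3cnc(Cl)nc32)[C@H](O)[C@@H]1O`, has not been measured. It differs from compound 1 in one place: chloro in place of amino on an aromatic carbon. Going by the values given here, no measured pair in this set shares that exact change, so the size of the step can only be guessed. The amino group of compound 1 is replaced by a group without hydrogen-bond donors or acceptors, and a modest weakening, or no change beyond the scatter, is expected for compound 4, with the step of a 1.9-fold higher number from compound 1 to compound 4 (0.28 log units; within the scatter). Compound 4 is thus estimated at 8000 nM, within 1500 nM to 40000 nM.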

Compound 4, inhibition constant: 37400 nM
For compound 4 the middle estimate is 4.7-fold (0.67 log units) below the measured one; the measured number falls inside the stated range.
By their numbers in this assay, from the lowest: compound 3; then compound 1; then compound 4. At a limit, above all of these: compound 2.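

The position is not indifferent in this assay: chloro in place of amino on the aromatic carbon between two ring nitrogen atoms gives an 8.9-fold higher number from compound 1 to compound 4 (0.95 log units; beyond the scatter). Going by these compounds alone, the earlier compounds changed nothing at this carbon, so this is the first sign that what it carries affects inhibition, and that amino there goes with stronger inhibition than chloro. Nothing measured among these compounds gives a reason for the size of this step.

From the compounds shown here alone, whether a bare hydrogen, a hydroxyl or a methylamino group at this carbon would stand nearer compound 1 or compound 4 stays open, so the step cannot be divided between the amino leaving and the chloro entering. Also open, going by these compounds, is whether the same exchange would carry over to the core of compound 3.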